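The source may report more compounds than this note shows. Statements on the series, on what has been measured and on what is new or still open speak of the compounds shown alone.

Measured in an assay on HEK293 cells for displacement of a labelled ligand from NPC1-like intracellular cholesterol transporter 1 (Homo sapiens); on this read-out higher numbers stand for weaker inhibition and lower numbers for stronger inhibition:
compound 1, `CC(C)(C)c1ccc(C(=O)N2CCC3(CC2)C(=O)N(CC(=O)N2CCC(CCO)CC2)CN3c2ccccc2)cc1`, 2600 nM
compound 2, `CCOC(=O)C1CCN(C(=O)CN2CN(c3ccccc3)C3(CCN(C(=O)c4ccc(C5CCCCC5)cc4)CC3)C2=O)CC1`, 900 nM

Among these two numbers compound 2 holds the lowest. Its nearest neighbour is compound 1, whose number is higher by a margin beyond the scatter of repeat measurements. The two compounds differ from each other in more than one place, so the two values are taken as they stand and no single change is credited with the gap between them.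

Compound 3, `O=C(CN1CN(c2ccccc2)C2(CCN(C(=O)c3ccc(C4CCCCC4)cc3)CC2)C1=O)N1CCC(CO)CC1`, is not yet measured in this assay. It differs from compound 2 in one place: hydroxymethyl in place of ethoxycarbonyl on a saturated ring carbon, in words hydroxymethyl in place of ethoxycarbonyl on a saturated ring carbon. Within the data shown here, no measured pair in the set isolates this exchange on a shared core, so the expectation rests on the two values at hand and on the small size of the change. The expected step is a 1.7-fold higher number from compound 2 to compound 3 (0.22 log units; within the scatter), modest and leaning towards a weaker number, and it may well fall within the scatter. Compound 3 is accordingly estimated at 1500 nM in this assay, with a range from 600 nM to 4000 nM.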

Compound 3, half-maximal inhibitory concentration: 1100 nM
Estimate against measurement, compound 3: 1.4-fold (0.13 log units) above; low and high end bracket the measured number.
By their numbers in this assay, from the lowest: compounds 2 and 3 (each within the scatter of the next); then compound 1.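

In this assay, going from 4-(ethoxycarbonyl)piperidin-1-yl to 4-(hydroxymethyl)piperidin-1-yl gives a 1.2-fold higher number from compound 2 to compound 3 (0.09 log units; within the scatter), the first one-place comparison available in the series. At this saturated ring carbon, three ring bonds from the ring nitrogen, the two groups cannot be told apart on this read-out, although ethoxycarbonyl has 5 heavy atoms and hydroxymethyl 2. The same holds although the exchange removes a group with 0 hydrogen-bond donors and 2 hydrogen-bond acceptors and brings in one with 1 hydrogen-bond donor and 1 hydrogen-bond acceptor; no measurement at hand explains why the values stay this close.

Still open, from the compounds shown here alone, is whether this position stays equally undiscriminating with a carboxylic acid, an aminomethyl group or a longer alkyl chain on the same ring carbon, as the two groups compared here give no reading for any of these. Compound 1 differs from compound 3 in more than one place, so the pair cannot show whether the gap seen for compound 1 comes from the chain on the piperidine ring or from elsewhere in the molecule.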